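Moving the Chlorine on the Phenyl Group

A few compounds are considered here, and "the series" means these few. Any claim that something is new, unique, unknown or untested is made for them only; others in the source may bear on it.

Of the compounds shown here, three built on one shared core have been measured in a functional assay on SF-268 cells (Homo sapiens) for cytotoxicity, read by sulforhodamine B assay, with a stated time of 48 h; a higher number here means a weaker inhibitor of growth, a lower number a stronger inhibitor of growth. Compound 1 `CC1=C(C(=O)Nc2ccc(F)c(Cl)c2)C(c2cccc(O)c2)NC(=S)N1` gives 17800 nM. Compound 2 `CC1=C(C(=O)Nc2ccc(F)c(Cl)c2)C(c2cccc(Oc3ccccc3)c2)NC(=O)N1` gives 8510 nM. Compound 3 `CC1=C(C(=O)Nc2ccc(F)c(Cl)c2)C(c2ccccc2Cl)NC(=S)N1` gives 14800 nM. Compound 3 holds the second highest of the three numbers; its nearest neighbour is compound 1 and its furthest is compound 2, and both gaps lie within the scatter, so the three cannot be ranked on these numbers.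

Compound 4 `CC1=C(C(=O)Nc2ccc(F)c(Cl)c2)C(c2cccc(Cl)c2)NC(=S)N1` differs from compound 3 in one place: 3-chlorophenyl in place of 2-chlorophenyl on a saturated ring carbon.

Among the compounds with values here, only one measured step changes the same ring carbon: a 1.2-fold lower number from compound 1 to compound 3 (0.08 log units; within the scatter). That step replaced one phenyl group with a quite different one and still produced nothing beyond the scatter. Within the data shown here, no measured step exchanges 2-chlorophenyl for 3-chlorophenyl, so there is no direct precedent for the change at hand. Because a 1.2-fold lower number from compound 1 to compound 3 (0.08 log units; within the scatter) stayed within the scatter, a number close to that of compound 3 is expected for compound 4, with a wide range to allow for the missing precedent. The expected step is no change at the digits printed from compound 3 to compound 4 (within the scatter). For compound 4 the estimate in this assay is 14800 nM, within a range from 7000 nM to 30000 nM.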

Compound 4, concentration for 50% growth inhibition: 10000 nM
Compound 4: middle estimate off by 1.5-fold (0.17 log units), on the high side, and the stated range covers the measured number.
By their numbers in this assay, from the lowest: compounds 2, 4, 3 and 1 (each within the scatter of the next, the first and the last beyond it).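

Moving the chlorine, with 3-chlorophenyl in place of 2-chlorophenyl on the saturated ring carbon, gives a 1.5-fold lower number from compound 3 to compound 4 (0.17 log units; within the scatter) in this assay, the first direct look at where the chlorine sits on this phenyl group, and the two arrangements cannot be told apart on these numbers. Chloro in place of hydroxy on an aromatic carbon, which turns 3-hydroxyphenyl into 3-chlorophenyl, gives a 1.8-fold lower number from compound 1 to compound 4 (0.25 log units; within the scatter), so this exchange, with the same attachment point kept on the phenyl group, does not separate the compounds either; at this position, then, neither the place of the chlorine nor its exchange for hydroxy moves the number past the usual variation between repeats. No measurement is at hand that could explain the small differences seen here.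

Going by these compounds, it remains open whether an amine, a carboxylic acid or a longer chain such as butyl on this phenyl group would produce a step beyond the scatter, or whether this position tolerates nearly anything. Also open, on these data alone, is whether these steps would look the same on other cell types or over a different exposure time.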